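Varying the Chain-End Amine on a Shared Core

The source may hold more compounds than are shown below. What is called first, only, known or untested is meant among the compounds shown, and "the series" means these compounds.

Compound 1 `CCN(CC)CCCNC(=O)C(c1ccccc1)c1ccccc1` gives 4400 nM in an assay on CHO cells for inhibition of sodium channel protein type 2 subunit alpha (Rattus norvegicus); a lower number here means a stronger inhibitor, a higher number a weaker inhibitor.
Compound 2 `CC1CCC(C)N1CCCNC(=O)C(c1ccccc1)c1ccccc1` gives 4600 nM in this assay.
Compound 3 `CC1CN(CCCNC(=O)C(c2ccccc2)c2ccccc2)CC(C)O1` gives 2700 nM in this assay.

Compound 3 carries the lowest of the three numbers, but the steps leading to it, a 1.6-fold lower number from compound 1 to compound 3 (0.21 log units; within the scatter) and a 1.7-fold lower number from compound 2 to compound 3 (0.23 log units; within the scatter), both stay within the scatter, as does a 1.0-fold higher number from compound 1 to compound 2 (0.02 log units; within the scatter). No order among the three can therefore be claimed; the three amines at the chain end read as interchangeable on these numbers.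

Compound 4 `CN1CCN(CCCNC(=O)C(c2ccccc2)c2ccccc2)CC1` continues this series with a further exchange at the same position: 4-methylpiperazin-1-yl in place of 2,6-dimethylmorpholin-4-yl on a saturated chain carbon, three bonds along the chain from an amide-type nitrogen. All three measured steps bear on it, since each also swaps one amine for another on the same saturated chain carbon, three bonds along the chain from the amide-type nitrogen, and none of them moved the number beyond the scatter. On that basis the step of a 1.3-fold higher number from compound 3 to compound 4 (0.11 log units; within the scatter) is expected to be small, without a clear direction, and to remain within the scatter. For compound 4 the estimated value in this assay is 3500 nM, with a range from 1500 nM to 8000 nM.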

Compound 4, half-maximal inhibitory concentration: > 200000 nM
Compound 4 gave a limit, no number; the forecaster's own chance of this, stated with the estimate: 5%; middle value at least 57-fold (1.75 log units) away from the limit.
By their numbers in this assay, from the lowest: compounds 3, 1 and 2 (each within the scatter of the next). At a limit, above all of these: compound 4.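

Compound 4 gives no number in this assay, only a limit of the assay: the limit of > 200000 nM in this assay, at which 1 of the 4 values shown sits. Three amines had read as interchangeable on the saturated chain carbon, three bonds along the chain from the amide-type nitrogen, but this position does not accept every amine, as the 4-methylpiperazin-1-yl group gives an at least 74-fold higher number from compound 3 to compound 4 (1.86 log units; beyond the scatter), together with an at least 43-fold higher number from compound 2 to compound 4 (1.63 log units; beyond the scatter) and an at least 45-fold higher number from compound 1 to compound 4 (1.65 log units; beyond the scatter), all beyond the scatter. The closest exchange is from 2,6-dimethylmorpholin-4-yl, which shares with 4-methylpiperazin-1-yl a six-membered non-aromatic ring with 2 hetero atoms and the same counts of hydrogen-bond donors and acceptors, so those shared features do not protect against the loss, and the difference lies in the ring atoms and their methyl groups.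

From the compounds shown here alone, how large the step really is stays open, since one end of it is a limit, and so does which part of the 4-methylpiperazin-1-yl group carries it. A plain piperazin-1-yl, a morpholin-4-yl without its methyl groups or a piperidin-1-yl at this position could show whether the second ring nitrogen or its methyl group separates compound 4 from compound 3.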